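The source may hold more compounds than are shown below. What is called first, only, known or untested is meant among the compounds shown, and "the series" means these compounds.

Of the compounds shown here, three sharing one core have been measured in a functional assay on MGC-803 cells (Homo sapiens) for cytotoxicity, read by MTT assay, with a stated time of 72 h; a higher number here means a weaker inhibitor, a lower number a stronger inhibitor. Compound 1 `CCCCCCNc1nc(SCc2ccc(C(F)(F)F)cc2)nc2ccccc12` gives 13100 nM. Compound 2 `Cc1ccccc1Nc1nc(SCc2ccc(C(F)(F)F)cc2)nc2ccccc12` gives 24400 nM. Compound 3 `O=[N+]([O-])c1cccc(Nc2nc(SCc3ccc(C(F)(F)F)cc3)nc3ccccc23)c1` reaches only a limit of the assay, > 50000 nM, so no number is known for it. Compound 3 thus stands at the limit of > 50000 nM in this assay, at which 1 of the 3 values shown sits. The measured steps read an at least 3.8-fold higher number from compound 1 to compound 3 (0.58 log units; beyond the scatter) and an at least 2.0-fold higher number from compound 2 to compound 3 (0.31 log units; beyond the scatter), while a 1.9-fold higher number from compound 1 to compound 2 (0.27 log units; within the scatter).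

Compound 4 `CCOc1ccc(Nc2nc(SCc3ccc(C(F)(F)F)cc3)nc3ccccc23)cc1` differs from compound 3 by 4-ethoxyphenyl in place of 3-nitrophenyl on a nitrogen on an aromatic ring. For the measured compounds named here, no measured step involves a 4-ethoxyphenyl group, so the known steps bear on it only indirectly: both steps into compound 3 end at the limit, and the one aryl group with a number, in compound 2, sits close to the hexyl of compound 1. For compound 4 a step of an at least 2.0-fold lower number from compound 3 to compound 4 (0.30 log units; that floor lies within the scatter) in this assay is therefore expected, since a 4-ethoxyphenyl is an aryl group like that of compound 2 rather than a nitro-bearing one. Compound 4 is estimated at 25000 nM, with a range from 8000 nM to 70000 nM, though another limit value remains possible.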

Compound 4, half-maximal inhibitory concentration: 37000 nM
The estimate for compound 4 lay 1.5-fold (0.17 log units) below the measured number, and the stated range covers the measured number.
By their numbers in this assay, from the lowest: compounds 1, 2 and 4 (each within the scatter of the next, the first and the last beyond it). At a limit, above all of these: compound 3.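

In this assay, compound 4 gives a second aryl group on this nitrogen with a real number, and a 1.5-fold higher number from compound 2 to compound 4 (0.18 log units; within the scatter), so 4-ethoxyphenyl and 2-methylphenyl cannot be told apart here. Against the hexyl of compound 1, however, an aryl group now gives a change beyond the scatter, a 2.8-fold higher number from compound 1 to compound 4 (0.45 log units; beyond the scatter), which compound 2 did not show. The step of an at least 1.3-fold lower number from compound 3 to compound 4 (0.13 log units; that floor lies within the scatter) gives only a floor, and compound 3 remains at a limit of the assay rather than a number: the limit of > 50000 nM in this assay, at which 1 of the 4 values shown sits.

As far as these compounds go, how far compound 3 actually lies from compound 4 therefore stays unknown. Also open, from the compounds shown here alone, is whether a chain longer than hexyl on this nitrogen, or an amine or a carboxylic acid in place of the ethoxy group, would lower the number.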